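The compounds below may be only part of what the source reports. "The series", "measured", "known", "first", "only" and "open" are said of these compounds alone.

Compound 1, `Nc1cc(N)c2nc(-c3ccccc3)c(Sc3ccc(F)cc3)nc2c1`, gives 40700 nM in a functional assay on LOX IMVI cells (Homo sapiens) for inhibition, read by sulforhodamine B assay, with a stated time of 48 h; a higher number here means a weaker inhibitor of growth, a lower number a stronger inhibitor of growth. Compound 3, `COc1cc(CNc2nc3cc(N)cc(N)c3nc2-c2ccccc2)cc(OC)c1OC`, gives 10500 nM in this assay. Compound 2, `Nc1cc(N)c2nc(-c3ccccc3)c(Oc3ccc(F)cc3)nc2c1`, reaches only a limit of this assay, < 100000 nM.

Compound 3 stands lowest of the two numbers, with compound 1 next and a gap beyond the usual scatter between them. Compound 4, `COc1ccc(CNc2nc3cc(N)cc(N)c3nc2-c2ccccc2)cc1OC`, differs from compound 3 in one place: hydrogen in place of methoxy on an aromatic carbon. Going by the values given here, the single measured step, a step that the limit leaves unreadable from compound 1 to compound 2, concerns an unrelated change and is itself unreadable, so no measured step bears on the removal of a methoxy group. For compound 4 the expected step is therefore a 1.1-fold higher number from compound 3 to compound 4 (0.06 log units; within the scatter), none beyond the scatter. Compound 4 is estimated at 12000 nM, within 4000 nM to 36000 nM.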

Compound 4, concentration for total growth inhibition: 14100 nM
The estimate for compound 4 lay 1.2-fold (0.07 log units) below the measured number; the measured number falls inside the stated range.
By their numbers in this assay, from the lowest: compounds 3 and 4 (each within the scatter of the next); then compound 1.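

In this assay, hydrogen in place of methoxy, on an aromatic carbon ortho to a methoxy group, gives a 1.3-fold higher number from compound 3 to compound 4 (0.13 log units; within the scatter), so at this position the methoxy group can be lost with no change that can be told from the scatter. Going by these compounds alone, the earlier compounds offered no readable step on this ring, and this is the first reading of the change. Nothing measured here bears on why the step is this size.

The compounds shown leave open whether a hydroxyl, a fluorine or an amine at this position would read the same. They also leave open what losing the two remaining methoxy groups would do.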